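Chloro purine benzyl chlorides: second chloro on the core

The compounds below may be only part of what the source reports. "The series", "measured", "known", "first", "only" and "open" are said of these compounds alone.

Measured so far:
compound 1 `ClCc1ccc(Cn2cnc3c(Cl)ncnc32)cc1` — 21900 nM
compound 2 `ClCc1ccc(Cn2cnc3nc(Cl)nc(Cl)c32)cc1` — > 100000 nM

The series is read in a functional assay on SNB-19 cells (Homo sapiens) for cytotoxicity, read by sulforhodamine B assay, with a stated time of 48 h; a higher number here means a weaker inhibitor of growth, a lower number a stronger inhibitor of growth. Among the measured compounds shown here, compound 1 gives 21900 nM, the only number obtained so far in this assay. Compound 2, which also carries two chloro groups on its core, returns only a limit of the assay at > 100000 nM; this is the edge described by the limit of > 100000 nM in this assay, at which 1 of the 2 values shown sits, not a measured concentration. Compound 1 therefore stands as the single quantified point, with compound 2 sitting outside the measurable range.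

Compound 3 `ClCc1ccc(Cn2cnc3c(Cl)nc(Cl)nc32)cc1` is not yet measured. It differs from compound 1 by chloro in place of hydrogen on an aromatic carbon, in words chloro in place of hydrogen on an aromatic carbon. For the measured compounds named here, no step between two measured compounds is available, so the expectation rests on the two values alone. Given that compound 2 with two chloro groups reaches only the limit at > 100000 nM, the second chloro in compound 3 is expected to weaken growth inhibition, with a step of a 2.3-fold higher number from compound 1 to compound 3 (0.36 log units; beyond the scatter) from compound 1 to compound 3 exceeding the usual scatter. Compound 3 is estimated at 50000 nM, expected range 15000 nM to 160000 nM.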

Compound 3, concentration for total growth inhibition: 7080 nM
Compound 3: the middle estimate sits 7.1-fold (0.85 log units) above what was measured, outside the stated range (below it).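

In this assay, chloro in place of hydrogen on an aromatic carbon, here the carbon between two ring nitrogen atoms, gives a 3.1-fold lower number from compound 1 to compound 3 (0.49 log units; beyond the scatter). Among the compounds shown here, this is the first step that can be read as a number, and it shows that a second chloro on the shared core can go with stronger growth inhibition at this position. A second chloro therefore does not by itself mean a loss of growth inhibition, and compound 2, which also carries two chloro groups on its core, returns only a limit, not a number: the limit of > 100000 nM in this assay, at which 1 of the 3 values shown sits.

The compounds shown leave open whether the step belongs to chloro specifically or would also appear with another group at this position, such as an amine or a methoxy group, and they give no reason for it. Going by these compounds, it also remains open what replacing the chloromethyl group, shared by all the compounds, with a hydroxymethyl group would do to growth inhibition.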